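Amide swap on the shared core: thiazolyl to 3-chlorophenyl

The source may report more compounds than this note shows. Statements on the series, on what has been measured and on what is new or still open speak of the compounds shown alone.

Compound 2 `COc1ccc(C(=O)Nc2nccs2)cc1Nc1nccc(-c2cccnc2)n1` carries a 1,3-thiazol-2-yl on the amide nitrogen of the shared core. In a functional assay on K562 cells (Homo sapiens) for antiproliferative activity, read by MTT assay, with a stated time of 48 h (on this read-out higher numbers stand for weaker inhibition and lower numbers for stronger inhibition), compound 2 is recorded as "not determined" (no result reported); no result was reported. Compound 1 `COc1ccc(C(=O)Nc2ccc(Cl)cn2)cc1Nc1nccc(-c2cccnc2)n1` likewise is recorded as "not determined" (no result reported) in this assay. Among the compounds with values here, the only number in the set comes from compound 3 `COc1ccc(C(=O)Nc2cc(Br)cc(C(F)(F)F)c2)cc1Nc1nccc(-c2cccnc2)n1`, which in this assay gives 215000 nM, a weak inhibition. Compound 4 `COc1ccc(C(=O)Nc2cccc(Cl)c2)cc1Nc1nccc(-c2cccnc2)n1` differs from compound 2 by 3-chlorophenyl in place of 1,3-thiazol-2-yl on an amide-type nitrogen. Within the data shown here, no step between measured compounds exists here, so nothing in the set shows how this amide swap moves the read-out; the single number from compound 3 only marks the level at which a related arylamide sits, and it is a very high one. The step from compound 2 to compound 4 therefore cannot be sized from the data; the working assumption is a read-out near that of compound 3, possibly somewhat stronger, within a wide band. Compound 4 is expected to give 100000 nM in this assay, with a range of 20000 nM to 500000 nM.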

Compound 4, half-maximal inhibitory concentration: 237000 nM
The estimate for compound 4 lay 2.4-fold (0.37 log units) below the measured number; measured number inside the range.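

In this assay, the amide-type nitrogen now has two measured substituents: 3-chlorophenyl in place of 3-bromo-5-(trifluoromethyl)phenyl gives a 1.1-fold higher number from compound 3 to compound 4 (0.04 log units; within the scatter). This change removes the bromine and the trifluoromethyl and moves the chlorine, yet the two arylamides cannot be told apart on this read-out, so this one pair shows no gain or loss from the exchange. The steps involving compound 1 or compound 2 cannot be read, and nothing measured here offers an explanation for the level shared by compound 3 and compound 4.

From the compounds shown here alone, it remains open whether an unsubstituted phenyl, or a phenyl carrying a carboxylic acid or an aminomethyl group, would leave this level. Going by these compounds, the standing of the heteroaryl amides, 1,3-thiazol-2-yl included, also remains open.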